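The source may report more compounds than this note shows. Statements on the series, on what has been measured and on what is new or still open speak of the compounds shown alone.

Notes on the series. In a functional assay on MX1 cells (Homo sapiens) for inhibition, read by MTT assay, with a stated time of 120 h (on this read-out lower numbers stand for stronger inhibition and higher numbers for weaker inhibition), compound 2 `O=C(/C=C/c1ccc(NC(=O)Nc2ccc(Cl)c(C(F)(F)F)c2)cc1)NC1CCC1` gives 4530 nM, the lower of the two numbers at hand. Compound 3 `CC(NC(=O)c1cccc(-c2ccc(NC(=O)Nc3ccc(Cl)c(C(F)(F)F)c3)cc2)c1)c1ccccc1` gives 5240 nM in this assay, which sits within the scatter of compound 2, so no order between the two is read. Compound 1 `C/C(=C\c1ccc(NC(=O)Nc2ccc(Cl)c(C(F)(F)F)c2)cc1)C(=O)NC(C)c1ccccc1` reaches only the assay limit of > 50000 nM in this assay (the limit of > 50000 nM in this assay, at which 1 of the 3 values shown sits), a limit and not a number. The next step leads from compound 2 to compound 4 `CC(NC(=O)/C=C/c1ccc(NC(=O)Nc2ccc(Cl)c(C(F)(F)F)c2)cc1)c1ccccc1`, where (1-phenylethyl in place of cyclobutyl on an amide-type nitrogen). Within the data shown here, no step between measured compounds speaks directly to this exchange. In this assay the step of a 1.1-fold lower number from compound 2 to compound 4 (0.05 log units; within the scatter) is expected, that is none beyond the scatter. Compound 4 is estimated at 4000 nM, with a range from 1500 nM to 12000 nM.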

Compound 4, half-maximal inhibitory concentration: 3130 nM
Estimate against measurement, compound 4: 1.3-fold (0.11 log units) above, and the stated range covers the measured number.
By their numbers in this assay, from the lowest: compounds 4, 2 and 3 (each within the scatter of the next). At a limit, above all of these: compound 1.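

In this assay, the exchange on this amide-type nitrogen gives a 1.4-fold lower number from compound 2 to compound 4 (0.16 log units; within the scatter), so the four-membered ring and 1-phenylethyl cannot be ordered here. Compound 1 carries the same 1-phenylethyl group and gives > 50000 nM, a limit and not a number. The 1-phenylethyl group on this nitrogen therefore does not by itself go with the limit seen for compound 1: the limit of > 50000 nM in this assay, at which 1 of the 4 values shown sits.

Still open, on these data alone, is how a simple amine, a carboxylic acid or a longer alkyl chain at this nitrogen would read. As far as these compounds go, what sets compound 1 apart also remains open.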